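Shifting the Nitrogen in a Fused Bicyclic Amide

The source may report more compounds than this note shows. Statements on the series, on what has been measured and on what is new or still open speak of the compounds shown alone.

Compound 3 `CC#CC(CC(=O)O)c1ccc(OCc2ccc(C(=O)N3CCCc4ccccc43)s2)cc1` carries a 1,2,3,4-tetrahydroquinolin-1-yl group on the amide carbonyl of the shared core. In a functional assay on HEK293 cells for agonist activity at Free fatty acid receptor 1 (Homo sapiens), read by fluorescence and calcium flux (on this read-out higher numbers stand for an effect only at larger amounts of compound and lower numbers for an effect already at smaller amounts), compound 3 gives 80 nM, the lowest of the two numbers recorded. Compound 2 `CC#CC(CC(=O)O)c1ccc(OCc2ccc(C(=O)N3CCN(c4ccccc4F)CC3)s2)cc1` gives 113 nM in this assay, a value within the scatter of that of compound 3. Compound 1 `CC#CC(CC(=O)O)c1ccc(OCc2ccc(C(=O)N3CCN(C)CC3)s2)cc1` reaches only a limit of this assay, reported as > 5000 nM. Replacing the methyl of compound 1 with 2-fluorophenyl gave an at least 44-fold lower number from compound 1 to compound 2 (1.64 log units; beyond the scatter), and exchanging the whole 4-methylpiperazin-1-yl for 1,2,3,4-tetrahydroquinolin-1-yl gave an at least 62-fold lower number from compound 1 to compound 3 (1.79 log units; beyond the scatter); both steps start from the limit of > 5000 nM in this assay, at which 1 of the 3 values shown sits, so their full size is not known. Compound 4 `CC#CC(CC(=O)O)c1ccc(OCc2ccc(C(=O)N3CCc4ccccc4C3)s2)cc1` differs from compound 3 by 1,2,3,4-tetrahydroisoquinolin-2-yl in place of 1,2,3,4-tetrahydroquinolin-1-yl on a carbonyl carbon. Neither measured step involves rearranging a fused bicyclic amine, so they offer no direct guide to this change. The expected outcome of this change is a 1.4-fold higher number from compound 3 to compound 4 (0.14 log units; within the scatter), an estimated step that stays within the scatter. The estimate for compound 4 is 110 nM, ranging from 40 nM to 350 nM.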

Compound 4, half-maximal effective concentration: 57 nM
Beside the measured number, compound 4's estimate is 1.9-fold (0.29 log units) above it, within the range that was stated.
By their numbers in this assay, from the lowest: compounds 4, 3 and 2 (each within the scatter of the next). At a limit, above all of these: compound 1.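

Among these compounds, the exchange of 1,2,3,4-tetrahydroquinolin-1-yl for 1,2,3,4-tetrahydroisoquinolin-2-yl on the carbonyl carbon gives a 1.4-fold lower number from compound 3 to compound 4 (0.15 log units; within the scatter) in this assay and is the first measured rearrangement of a fused bicyclic amine here. With the same atoms joined differently, the two amides cannot be told apart on this read-out, so this assay does not separate the two positions of the ring nitrogen. As far as these compounds go, exchanging the whole 4-methylpiperazin-1-yl for 1,2,3,4-tetrahydroisoquinolin-2-yl gives an at least 87-fold lower number from compound 1 to compound 4 (1.94 log units; beyond the scatter), and the full size of that step is unknown because it starts from a limit: the limit of > 5000 nM in this assay, at which 1 of the 4 values shown sits.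

Still open, from the compounds shown here alone, is how the result would change with indolin-1-yl, whose non-aromatic ring is five-membered. Going by these compounds, it is also open what a fluorine or a methoxy group on the six-membered aromatic ring of 1,2,3,4-tetrahydroisoquinolin-2-yl would do.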